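This account rests on a few compounds, and the source may have more. Where it says the series, first, only, none or still open, it means among the compounds named here.

Of the compounds shown here, three have so far been measured in an assay on BaF3 cells for inhibition of proto-oncogene tyrosine-protein kinase receptor Ret (Homo sapiens), read by MTT assay, with a stated time of 48 h; a higher number here means a weaker inhibitor of growth, a lower number a stronger inhibitor of growth. Compound 1, `Nc1ncnc2c1c(-c1cc(C3CC3)on1)nn2C1CCCCC1`, gives 520 nM in this assay. Compound 2, `CC(C)n1nc(-c2cc(-c3ccccc3)on2)c2c(N)ncnc21`, gives 3460 nM in this assay. Compound 3, `CC(C)n1nc(/C=N/OCc2ccccc2)c2c(N)ncnc21`, gives 7410 nM in this assay. Compound 1 therefore stands at the lowest number of the three, meaning the strongest inhibition of growth: compound 2 is nearest to it and compound 3 furthest, and both gaps lie beyond the usual scatter of repeated measurements. None of the three measured compounds differs from another in a single place, so no single structural step can be read off from them.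

Compound 4, `Cn1nc(-c2cc(C3CC3)on2)c2c(N)ncnc21`, has not yet been measured in this assay. It differs from compound 1 in one place: methyl in place of cyclohexyl on an aromatic nitrogen. Among the measured compounds shown here, the measured compounds give no example of exchanging the group on that aromatic nitrogen, so the expectation rests on the change itself, a methyl in place of a cyclohexyl. The step of a 4.8-fold higher number from compound 1 to compound 4 (0.68 log units; beyond the scatter) is expected to move the number upward, towards weaker inhibition of growth, by more than the scatter. Compound 4 is accordingly estimated at 2500 nM in this assay, with a range from 700 nM to 9000 nM.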

Compound 4, concentration for 50% growth inhibition: 2670 nM
Beside the measured number, compound 4's estimate is 1.1-fold (0.03 log units) below it; the measured number falls inside the stated range.
By their numbers in this assay, from the lowest: compound 1; then compounds 4 and 2 (each within the scatter of the next); then compound 3.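

Among the compounds shown here, this is the first pair that differs in one place, so the group on the aromatic nitrogen can now be judged on its own. In this assay, with the 5-cyclopropyl-1,2-oxazol-3-yl group and the rest of the core unchanged, methyl in place of cyclohexyl gives a 5.1-fold higher number from compound 1 to compound 4 (0.71 log units; beyond the scatter) and thus moves the number towards weaker inhibition of growth. The position is therefore not indifferent to what it carries, since this step lies beyond the scatter, although compound 4 shows that a group of 1 heavy atom, with no ring, still leaves a measurable number in this pair.

No measurement shown explains why the number moves with this exchange. For the compounds shown here, with only this one exchange at the nitrogen, it remains open whether the number follows the ring itself or the count of carbons, and how a cyclopentyl ring, a straight butyl chain or a piperidine ring, which carries an amine, would compare with cyclohexyl and methyl.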